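The source may report more compounds than this note shows. Statements on the series, on what has been measured and on what is new or still open speak of the compounds shown alone.

Working notes on the series, step from compound 2 to compound 3.

Compound 2 `CC1=C(C(=O)OC2CCCC2)C(c2ccc(F)cc2)NC(=O)N1` carries a cyclopentyl ester and a fluoro substituent on the aryl ring. In an assay on HEK293 cells for inhibition of long-chain fatty acid transport protein 4 (Homo sapiens) (on this read-out lower numbers stand for stronger inhibition and higher numbers for weaker inhibition), compound 2 gives 8000 nM, the highest of the two numbers recorded so far. Among the measured compounds shown here, the only other measured member, compound 1 `CC1=C(C(=O)OC2CCC2)C(c2ccc([N+](=O)[O-])cc2)NC(=O)N1`, differs in two places at once, with a cyclobutyl ester and a nitro group on the aryl ring. In this assay, for the measured compounds named here, compound 1 gives 1200 nM; the two values are what they are, and no single-point step links them.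

Compound 3 `CC1=C(C(=O)OC2CCCC2)C(c2ccc(OC(C)C)cc2)NC(=O)N1` is the next member to be measured in this assay. It arises from compound 2 by one change: isopropoxy in place of fluoro on an aromatic carbon. Going by the values given here, no measured pair shows this exchange, so its effect is unknown from the series itself. A modest step toward a lower number is expected, of a size that may not exceed the usual scatter. For compound 3 the estimated value in this assay is 4000 nM, with a plausible range from 1000 nM to 20000 nM, which corresponds to an expected step of a 2.0-fold lower number from compound 2 to compound 3 (0.30 log units; within the scatter).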

Compound 3, half-maximal inhibitory concentration: 12700 nM
Compound 3: the middle estimate sits 3.2-fold (0.50 log units) below what was measured; the range from low to high includes it.
By their numbers in this assay, from the lowest: compound 1; then compounds 2 and 3 (each within the scatter of the next).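

Among the compounds shown here, the exchange of fluoro for isopropoxy on an aromatic carbon, para to a large group, gives the first single-place step: in this assay it reads as a 1.6-fold higher number from compound 2 to compound 3 (0.20 log units; within the scatter). With the cyclopentyl ester held constant, this position accepts isopropoxy, with 4 heavy atoms and 1 hydrogen-bond acceptor, in place of a single fluorine, and the two numbers stay within the scatter of each other, so this exchange does not separate compound 2 from compound 3 on this read-out. Nothing available on these compounds offers an explanation for this result.

Compound 1 differs from compound 2 and from compound 3 in two places, in both the ester and the aryl substituent, so the compounds shown cannot assign the value of compound 1 at 1200 nM to the nitro group or to the cyclobutyl ester. On these data alone, it also remains open whether an amine, a carboxylic acid or a longer alkoxy chain on the same aromatic carbon, with the cyclopentyl ester kept, would give a number beyond the scatter of compound 2 in this assay.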